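The compounds below may be only part of what the source reports. "The series", "measured", "known", "first", "only" and "open" are said of these compounds alone.

Compound 1 `CS/C(=N\C(=O)c1cc(-c2ccccc2)nc2ccccc12)NC(=O)c1cc(-c2ccccc2)nc2ccccc12` and compound 2 `C[Se]/C(=N\C(=O)c1cc(-c2ccccc2)nc2ccccc12)NC(=O)c1cc(-c2ccccc2)nc2ccccc12` share one core, while compound 3 `C[Se]/C(=N\C(=O)c1cnc2ccccc2c1)NC(=O)c1cnc2ccccc2c1` and compound 4 `CS/C(=N\C(=O)c1cnc2ccccc2c1)NC(=O)c1cnc2ccccc2c1` share another; the difference between the two cores is not broken down here. In a functional assay on PC-3 cells (Homo sapiens) for cytotoxicity, read by MTT assay, with a stated time of 72 h (a lower number here means a stronger inhibitor of growth, a higher number a weaker inhibitor of growth), compound 1 gives only a limit, > 100000 nM. In this assay compound 2 gives 40200 nM and compound 3 gives 43600 nM. The change from compound 2 to compound 1 is a group of 2 heavy atoms (1 carbon, 1 sulfur; no ring) in place of a group of 2 heavy atoms (1 carbon, 1 selenium; no ring), on a carbon with a double bond to nitrogen, and it gave an at least 2.4-fold higher number from compound 2 to compound 1 (0.39 log units; beyond the scatter), a step that runs into (the limit of > 100000 nM in this assay, at which 1 of the 3 values shown sits). Compound 4 carries the same change, (a group of 2 heavy atoms (1 carbon, 1 sulfur; no ring) in place of a group of 2 heavy atoms (1 carbon, 1 selenium; no ring), on a carbon with a double bond to nitrogen). Because an at least 2.4-fold higher number from compound 2 to compound 1 (0.39 log units; beyond the scatter) was at least modest, a step of similar size is expected here, a 2.5-fold higher number from compound 3 to compound 4 (0.40 log units; beyond the scatter). Compound 4 is therefore estimated at 110000 nM, within a range of 50000 nM to 250000 nM, with a real chance that only a limit is reported.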

Compound 4, concentration for total growth inhibition: > 100000 nM
Compound 4 was reported as a limit; the forecaster's own chance of this, stated with the estimate: 60%; the middle value is on the limit's open side.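

Replacing the selenium group with methylsulfanyl gave an at least 2.2-fold higher number from compound 3 to compound 4 (0.36 log units; beyond the scatter) in this assay, and the same change on the other core points the same way: the same change on two cores in this assay, an at least 2.4-fold higher number (0.39 log units; beyond the scatter) from compound 2 to compound 1 and an at least 2.2-fold higher number (0.36 log units; beyond the scatter) from compound 3 to compound 4; the limit leaves it open whether they differ.
So among the compounds shown, the sulfur compound is the weaker inhibitor of growth on both cores, and no pair goes against this.
On these data alone, the result for compound 4 is a limit and not a number, as is that for compound 1, so the true size of the step on either core remains unknown: the limit of > 100000 nM in this assay, at which 2 of the 4 values shown sit.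

As far as these compounds go, whether the change behaves the same way on any further core remains open. Also open, from the compounds shown here alone, is how a longer chain or an amine would read in this assay in place of methylsulfanyl on the carbon with a double bond to nitrogen.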